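Urea series: chain length on the para-substituted ring

The compounds below may be only part of what the source reports. "The series", "measured", "known", "first", "only" and "open" are said of these compounds alone.

Measured compounds in an assay on isolated protein for inhibition of acyl-CoA:cholesterol acyltransferase (Oryctolagus cuniculus); on this read-out higher numbers stand for weaker inhibition and lower numbers for stronger inhibition:
compound 1 `CCCCCCCCc1ccc(NC(=O)Nc2c(C(C)C)cccc2C(C)C)cc1` gives 11 nM
compound 2 `CCc1ccc(NC(=O)Nc2c(C(C)C)cccc2C(C)C)cc1` gives 100 nM
compound 3 `CCCCCCCCCCCCc1ccc(NC(=O)Nc2c(C(C)C)cccc2C(C)C)cc1` gives 15 nM

Compound 3 sits next to compound 1, the two differing by a 1.4-fold higher number from compound 1 to compound 3 (0.13 log units; within the scatter); the gap to compound 2 is larger, a 6.7-fold lower number from compound 2 to compound 3 (0.82 log units; beyond the scatter). Compound 4 `Cc1ccc(NC(=O)Nc2c(C(C)C)cccc2C(C)C)cc1` is not yet measured. It differs from compound 3 by hydrogen in place of undecyl on a saturated chain carbon bound to an aromatic carbon.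

For the measured compounds named here, two measured steps bear on this change. Shortening the chain gave a 9.1-fold higher number from compound 1 to compound 2 (0.96 log units; beyond the scatter), and lengthening it gave a 6.7-fold lower number from compound 2 to compound 3 (0.82 log units; beyond the scatter). Both steps point the same way: a shorter chain on this position goes with a higher number in this assay. Going by the values given here, compound 4 carries a chain shorter than any measured here, shorter even than that of compound 2, so a step at least as large as the one from compound 1 to compound 2 is expected, and possibly larger.

For compound 4 the expected step is a 20-fold higher number from compound 3 to compound 4 (1.30 log units; beyond the scatter). Compound 4 is therefore estimated at 300 nM, with a range from 100 nM to 1500 nM.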

Compound 4, half-maximal inhibitory concentration: 250 nM
Compound 4: middle estimate off by 1.2-fold (0.08 log units), on the high side; low and high end bracket the measured number.
By their numbers in this assay, from the lowest: compounds 1 and 3 (each within the scatter of the next); then compound 2; then compound 4.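

In this assay the trend continues below the shortest chain measured before, as hydrogen in place of methyl gives a 2.5-fold higher number from compound 2 to compound 4 (0.40 log units; beyond the scatter) and this smallest change at the position still lies beyond the scatter. Removing the long chains costs far more, with a 23-fold higher number from compound 1 to compound 4 (1.36 log units; beyond the scatter) and a 17-fold higher number from compound 3 to compound 4 (1.22 log units; beyond the scatter) both large, so the numbers fall along compound 4, compound 2 and compound 1, while compound 3 goes against any further gain, staying within the scatter of compound 1. No supporting data are available to explain these steps.

Still open, going by these compounds, is how the numbers behave for chains of intermediate length, since only compound 2 lies in the wide gap from compound 4 to compound 1. Also open, on these data alone, is whether a chain longer than that of compound 3, a branched chain, an amine or a carboxylic acid at this place would fit the same trend.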